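This account rests on a few compounds, and the source may have more. Where it says the series, first, only, none or still open, it means among the compounds named here.

Compound 2 `COc1cc(-c2nn(-c3cccc(NC(=O)c4ccc(Cl)c(C(F)(F)F)c4)c3)cc2-c2ccncc2)ccc1Cl` carries a pyridyl-substituted pyrazole linked through an anilide to a 4-chloro-3-(trifluoromethyl)phenyl amide. In a functional assay on K562 cells (Homo sapiens) for inhibition, read by sulforhodamine B assay, with a stated time of 48 h (a lower number here means a stronger inhibitor of growth, a higher number a weaker inhibitor of growth), compound 2 gives 1610 nM. Going by the values given here, the only other measured member of the series, compound 1 `O=C(Nc1cccc(-n2cc(-c3ccncc3)c(-c3ccc(Cl)c(O)c3)n2)c1)Nc1ccc(Cl)c(Cl)c1`, a urea analogue with a phenol in place of the methoxy group, gives in this assay a value of 1410 nM; the two numbers lie within the scatter of each other, so neither compound can be set apart from the other on these data.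

Compound 3 `COc1cc(-c2nn(-c3cccc(NC(=O)c4cccc(C(F)(F)F)c4)c3)cc2-c2ccncc2)ccc1Cl` is the unmeasured next member. Its difference from compound 2 is hydrogen in place of chloro on an aromatic carbon. Among the compounds with values here, no measured pair shows a step of this kind, so the direction rests on the change itself. A modest rise in number is expected, with the step from compound 2 to compound 3 estimated at a 1.7-fold higher number from compound 2 to compound 3 (0.24 log units; within the scatter), most of it possibly within the scatter. Compound 3 is therefore estimated at 2800 nM in this assay, with a range from 1200 nM to 7000 nM.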

Compound 3, concentration for 50% growth inhibition: 1400 nM
The estimate for compound 3 lay 2.0-fold (0.30 log units) above the measured number; the measured number falls inside the stated range.
By their numbers in this assay, from the lowest: compounds 3, 1 and 2 (each within the scatter of the next).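

Going by these compounds alone, the first reading at this position comes from the change from 4-chloro-3-(trifluoromethyl)phenyl to 3-(trifluoromethyl)phenyl: in this assay, hydrogen in place of chloro gives a 1.2-fold lower number from compound 2 to compound 3 (0.06 log units; within the scatter) and the two compounds cannot be told apart. On this pair, the chloro group ortho to the trifluoromethyl group and para to a large group is not needed to keep growth inhibition at the level of compound 2. No accompanying measurement bears on this result.

As far as these compounds go, it remains open whether this position tolerates a group larger or different in kind from chloro, such as an amine or a carboxylic acid. Also open, from the compounds shown here alone, is whether the trifluoromethyl group can give way to hydrogen or a methyl group without a step beyond the scatter.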